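Fluoro on the phenyl ring of compound 2

A few compounds are considered here, and "the series" means these few. Any claim that something is new, unique, unknown or untested is made for them only; others in the source may bear on it.

Among the measured compounds shown here, in a functional assay on HeLa cells (Homo sapiens) for cytotoxicity, read by MTT assay, with a stated time of 48 h (a higher number here means a weaker inhibitor, a lower number a stronger inhibitor), compound 2 `C=C1OC(=O)C=C1Cc1ccc(NC(=O)/C=C/c2ccccc2)cc1` gives 7340 nM, the lowest of the three numbers so far. Compound 1 `O=C(/C=C/c1ccccc1F)Nc1ccc(CC2=CC(=O)OC2)cc1` gives 45800 nM and compound 3 `C=C1OC(=O)C=C1Cc1ccc(NC(=O)c2ccccc2)cc1` gives 48300 nM, both beyond the scatter from compound 2.

Compound 4 `C=C1OC(=O)C=C1Cc1ccc(NC(=O)/C=C/c2ccccc2F)cc1` has not been measured and departs from compound 2 in one place: fluoro in place of hydrogen on an aromatic carbon. This is fluoro in place of hydrogen on an aromatic carbon.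

For the measured compounds named here, the only measured single-place step is a 6.6-fold higher number from compound 2 to compound 3 (0.82 log units; beyond the scatter), a modest change with phenyl in place of 2-phenylethenyl on a carbonyl carbon. It does not test fluoro. Compound 1 carries the 2-fluorophenyl group on a different core, so its 45800 nM does not isolate that change either. Going by the values given here, with no measured step on this substitution, no step beyond the scatter is expected in this assay, though the uncertainty is wide. For compound 4 the estimated value is 6500 nM, with an expected range of 2500 nM to 20000 nM. The estimate means a 1.1-fold lower number from compound 2 to compound 4 (0.05 log units; within the scatter).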

Compound 4, half-maximal inhibitory concentration: 6930 nM
Compound 4: middle estimate off by 1.1-fold (0.03 log units), on the low side; low and high end bracket the measured number.
By their numbers in this assay, from the lowest: compounds 4 and 2 (each within the scatter of the next); then compounds 1 and 3 (each within the scatter of the next).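

In this assay, among the compounds shown here, fluoro in place of hydrogen on an aromatic carbon, ortho to a large group, gives a 1.1-fold lower number from compound 2 to compound 4 (0.02 log units; within the scatter) and so marks the first direct reading of this change, with no step beyond the scatter on the shared core. With the 2-fluorophenyl group held constant, the change on the saturated chain carbon bound to an aromatic carbon gives a 6.6-fold lower number from compound 1 to compound 4 (0.82 log units; beyond the scatter) and separates the effect of that group from the effect of fluoro. No measurement available here explains the size of either step.

Still open, as far as these compounds go, is whether chloro, methoxy or trifluoromethyl at this place on the ring would also stay within the scatter of hydrogen. Also open, from the compounds shown here alone, is how an amine or a carboxylic acid on the same ring would read in this assay.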